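A few compounds are considered here, and "the series" means these few. Any claim that something is new, unique, unknown or untested is made for them only; others in the source may bear on it.

Working notes on the series, a set of cinnamamides on a shared core that differ only in the group on the pendant phenyl ring.

Compound 1, `COc1ccc(/C=C/C(=O)Nc2nnc(-c3ccc(Br)cc3)s2)cc1`, gives 1.13 ug/mL in a functional assay on MCF7 cells (Homo sapiens) for antiproliferative activity, read by MTT assay, with a stated time of 48 h; a lower number here means a stronger inhibitor, a higher number a weaker inhibitor. Compound 2, `COc1ccc(/C=C/C(=O)Nc2nnc(-c3ccc(C)cc3)s2)cc1`, gives 0.35 ug/mL. Among the compounds with values here, compound 3, `COc1ccc(/C=C/C(=O)Nc2nnc(-c3ccc(Cl)cc3)s2)cc1`, gives 0.91 ug/mL; on the numbers so far it stands second highest of the three, next to compound 1 and separated only from compound 2.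

The measured steps: a 3.2-fold lower number from compound 1 to compound 2 (0.51 log units; beyond the scatter), a 1.2-fold lower number from compound 1 to compound 3 (0.09 log units; within the scatter), and a 2.6-fold higher number from compound 2 to compound 3 (0.41 log units; beyond the scatter). Two halogens therefore give much the same number, while the methyl analogue stands apart.

Compound 4, `COc1ccc(/C=C/C(=O)Nc2nnc(-c3ccccc3)s2)cc1`, is the next member. Its change from compound 3 is hydrogen in place of chloro on an aromatic carbon. Within the data shown here, no measured step removes a substituent altogether, so the bearing of the data is indirect: the exchange of one halogen for another was flat, and only the methyl compound moved the number. With nothing to show that an unsubstituted ring behaves like the methyl one, the expectation for compound 4 is a number close to that of compound 3, the step of a 1.4-fold higher number from compound 3 to compound 4 (0.15 log units; within the scatter) being expected to stay within the scatter. Compound 4 is estimated at 1.3 ug/mL, with a range of 0.5 ug/mL to 3.5 ug/mL.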

Compound 4, half-maximal inhibitory concentration: 0.83 ug/mL
Compound 4: middle estimate off by 1.6-fold (0.19 log units), on the high side; measured number inside the range.
By their numbers in this assay, from the lowest: compound 2; then compounds 4, 3 and 1 (each within the scatter of the next).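

Taking the substituent away altogether leaves the number in this assay flat at this place on the pendant ring, para to a large group, with both halogen comparisons inside the scatter (a 1.1-fold lower number from compound 3 to compound 4 (0.04 log units; within the scatter)) and (a 1.4-fold lower number from compound 1 to compound 4 (0.13 log units; within the scatter)), so the unsubstituted ring sits with chloro and bromo and neither halogen separates from hydrogen. Within the data shown here, compound 2 is the one compound that goes against this grouping (a 2.4-fold higher number from compound 2 to compound 4 (0.38 log units; beyond the scatter)), which means that across these four compounds the methyl is the only group at this carbon that differs from hydrogen beyond the scatter, though the step is modest and rests on a single compound. Nothing in hand bears on this result, so the separation of compound 2 stands as an observation only.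

From the compounds shown here alone, it remains open whether the methyl result is particular to methyl or carries over to ethyl, methoxy or an amine at the same carbon. Going by these compounds, it is equally open whether trifluoromethyl or a carboxylic acid there would fall with hydrogen and the halogens or with compound 2.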